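A pyridine nitrogen moved around the ring

A few compounds are considered here, and "the series" means these few. Any claim that something is new, unique, unknown or untested is made for them only; others in the source may bear on it.

Of the compounds shown here, three sharing one core have been measured so far. Among the compounds with values here, in a functional assay on PC-3 cells (Homo sapiens) for inhibition (on this read-out higher numbers stand for weaker inhibition and lower numbers for stronger inhibition), compound 3 `Cc1c(C(=O)N/N=C\c2ccccc2)oc2cccc(O)c12` gives 29200 nM, the only plain number in the set. Compound 1 `Cc1c(C(=O)N/N=C\c2ccncc2)oc2cccc(O)c12` reaches only the assay limit of >= 40000 nM. Compound 2 `Cc1c(C(=O)N/N=C\c2cccc(F)c2)oc2cccc(O)c12` likewise stops at the limit of >= 40000 nM. Compound 4 `Cc1c(C(=O)N/N=C\c2cccnc2)oc2cccc(O)c12` is not yet measured and differs from compound 3 by pyridin-3-yl in place of phenyl on a carbon with a double bond to nitrogen. The closest guide is the step of an at least 1.3-fold lower number from compound 1 to compound 3 (0.13 log units; that floor lies within the scatter), whose floor lies within the scatter, together with the limit of >= 40000 nM in this assay, at which 2 of the 3 values shown sit. For compound 4 the expected step is therefore a 1.5-fold higher number from compound 3 to compound 4 (0.19 log units; within the scatter), a modest move toward weaker inhibition that may well end at the same limit. Compound 4 is estimated at 45000 nM, within 20000 nM to 120000 nM.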

Compound 4, half-maximal inhibitory concentration: >= 40000 nM
Compound 4: no number, only a limit; the forecaster's own chance of this, stated with the estimate: 60%; the middle value lies beyond the limit too.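

In this assay, pyridin-3-yl in place of phenyl gives an at least 1.3-fold higher number from compound 3 to compound 4 (0.13 log units; that floor lies within the scatter). Compound 4 has only a limit and no plain number, so moving the ring nitrogen from the pyridin-4-yl of compound 1 yields no readable value either. The steps among compound 1, compound 2 and compound 4 cannot be read, and the limit now covers most of the set: the limit of >= 40000 nM in this assay, at which 3 of the 4 values shown sit.

Still open, going by these compounds, is how pyridin-2-yl would read on this carbon. Also open, on these data alone, is whether a phenyl ring carrying an amine or a carboxylic acid would lower the number beyond the scatter.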